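Spiro-triazole series: compound 3 to compound 4

The source may hold more compounds than are shown below. What is called first, only, known or untested is meant among the compounds shown, and "the series" means these compounds.

Three members of the series have been measured in a functional assay on HepG2 cells (Homo sapiens) for antiproliferative activity, read by MTT assay, with a stated time of 48 h; on this read-out lower numbers stand for stronger inhibition and higher numbers for weaker inhibition. Compound 1 `N#CC1=C(N)Oc2c(c3nc4ccccc4nc3c3ccccc23)C12C(=O)N(Cc1cnnn1-c1ccccc1Br)c1ccccc12` gives > 50000 nM, which is a limit of the assay rather than a number. Compound 2 `Cc1ccc(-n2nncc2CN2C(=O)C3(C(C#N)=C(N)Oc4c3c3nc5ccccc5nc3c3ccccc43)c3ccccc32)cc1C` gives > 50000 nM, again a limit. Compound 3 `COc1ccccc1-n1nncc1CN1C(=O)C2(C(C#N)=C(N)Oc3c(N)cc4nc5ccccc5nc4c32)c2ccccc21` gives > 50000 nM, also a limit. Among the compounds with values here, the one measured change, a step that the two limits leave unreadable from compound 1 to compound 2, therefore cannot be read for size, as the limit of > 50000 nM in this assay, at which 3 of the 3 values shown sit, shows.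

Compound 4 `Cc1ccc(Cl)cc1-n1nncc1CN1C(=O)C2(C(C#N)=C(N)Oc3c(N)cc4nc5ccccc5nc4c32)c2ccccc21` differs from compound 3 in one place: 5-chloro-2-methylphenyl in place of 2-methoxyphenyl on an aromatic nitrogen

Within the data shown here, no measured step bears directly on this change. Compound 1 and compound 2 carry a different part of the core, and the pair differ among themselves only in the group on the aromatic nitrogen, where the step was unreadable. Compound 3 stands at the limit, so no direction can be taken from its neighbours.

With every value shown sitting at the limit, compound 4 is expected to remain there as well, and the expected step that the limit leaves unreadable from compound 3 to compound 4 is therefore none beyond the scatter. Compound 4 is estimated at 70000 nM in this assay, within a range from 20000 nM to 250000 nM.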

Compound 4, half-maximal inhibitory concentration: 17300 nM
Compound 4: the middle estimate sits 4.0-fold (0.61 log units) above what was measured; measured number below the stated range.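

In this assay, within the data shown here, with the shared core held fixed, 5-chloro-2-methylphenyl in place of 2-methoxyphenyl on the aromatic nitrogen gives an at least 2.8-fold lower number from compound 3 to compound 4 (0.46 log units; beyond the scatter), so this position can carry a readable difference, which the unreadable step among the earlier compounds could not show. Compound 4 is the only compound shown with a number rather than a limit, although it remains a weak inhibitor on this read-out, and the change removes the hydrogen-bond acceptor of the 2-methoxyphenyl group while the heavy-atom count stays the same. The step sets only a minimum, and its full size remains unknown: the limit of > 50000 nM in this assay, at which 3 of the 4 values shown sit.

The pair does not separate the contribution of the chlorine from that of the methyl, since both differ from the 2-methoxyphenyl group in a single change, so the 2-methylphenyl and 3-chlorophenyl groups would be the direct tests. Also open, going by these compounds, is whether the gain carries over to the core of compound 1 and compound 2, and how a phenyl group bearing an amine or a carboxylic acid would read at this position.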